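This account rests on a few compounds, and the source may have more. Where it says the series, first, only, none or still open, it means among the compounds named here.

Measured compounds:
compound 1, `COc1cc(C(F)(F)F)cc(C(F)(F)F)c1C(=O)NC1(c2ccccc2)CCCN(Cc2ccccc2)C1`, in an assay on cells for inhibition of sodium- and chloride-dependent glycine transporter 1 (Homo sapiens) (on this read-out lower numbers stand for an effect already at smaller amounts and higher numbers for an effect only at larger amounts of compound), gives 6700 nM
compound 2, `COc1cc(C(F)(F)F)cc(SC)c1C(=O)NC1(c2ccc(F)cc2)CCCN(C)C1`, in this assay gives 26 nM
compound 3, `COc1cc(C(F)(F)F)cc(SC)c1C(=O)NC1(c2ccc(C)cc2)CCCN(C)C1`, in this assay gives 230 nM

On these three numbers compound 3 stands second highest: compound 2 is the nearest, compound 1 the furthest. For the measured compounds named here, the only single-change step in the set is an 8.8-fold higher number from compound 2 to compound 3 (0.95 log units; beyond the scatter), which exchanges the fluoro on the aromatic carbon of compound 2 for the methyl of compound 3.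

Compound 4, `COc1cc(C(F)(F)F)cc(SC)c1C(=O)NC1(c2cccc(F)c2)CCCN(C)C1`, differs from compound 3 as follows: 3-fluorophenyl in place of 4-methylphenyl on a saturated ring carbon. This returns a fluoro substituent to the pendant aromatic ring, but not at the carbon it occupies in compound 2, so the step of an 8.8-fold higher number from compound 2 to compound 3 (0.95 log units; beyond the scatter) bears on it only in part. A lower number than that of compound 3 is expected, in the direction of compound 2, yet with the full reversal uncertain; the expected step is a 3.3-fold lower number from compound 3 to compound 4 (0.52 log units; beyond the scatter). The estimate for compound 4 in this assay is 70 nM, with a range from 20 nM to 250 nM.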

Compound 4, half-maximal effective concentration: 48 nM
Compound 4: the middle estimate sits 1.5-fold (0.16 log units) above what was measured; the measured number falls inside the stated range.
By their numbers in this assay, from the lowest: compounds 2 and 4 (each within the scatter of the next); then compound 3; then compound 1.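

At the saturated ring carbon, 3-fluorophenyl in place of 4-methylphenyl gives a 4.8-fold lower number from compound 3 to compound 4 (0.68 log units; beyond the scatter) in this assay. The step between the two fluorophenyl groups, a 1.8-fold higher number from compound 2 to compound 4 (0.27 log units; within the scatter), stays within the scatter, so this read-out does not separate them; among the three compounds with the same core, the number stands apart only with 4-methylphenyl. No measurement is at hand that accounts for this difference.

As far as these compounds go, whether the shift follows the methyl itself or its place on the pendant ring remains open; 3-methylphenyl, 2-fluorophenyl, 4-chlorophenyl or unsubstituted phenyl on the same carbon would bear on this. Also open, from the compounds shown here alone, is whether the equivalence of the two fluorophenyl groups would hold with an ethyl in place of the methyl on the ring nitrogen.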